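Swapping the para group on the sulfonamide ring of a ghrelin agonist

The source may report more compounds than this note shows. Statements on the series, on what has been measured and on what is new or still open speak of the compounds shown alone.

Measured compounds:
Compound 1, `COc1ccc(N2C[C@@H](C)N[C@@H](C)C2)cc1NS(=O)(=O)c1ccc(-c2ccncc2)cc1`: 316 nM
Compound 2, `COc1ccc(N2C[C@@H](C)N[C@@H](C)C2)cc1NS(=O)(=O)c1ccc(N2CCCC2=O)cc1`: 39.8 nM

In a functional assay for agonist activity at growth hormone secretagogue receptor type 1 (Homo sapiens), read by FLIPR (a lower number here means that less compound is needed, a higher number that more compound is needed for the effect), compound 1 gives 316 nM, while compound 2 gives 39.8 nM. Among the measured compounds shown here, of the two numbers, compound 2 has the lowest; its only neighbour is compound 1, and the step of a 7.9-fold lower number from compound 1 to compound 2 (0.90 log units; beyond the scatter) is beyond the scatter. That step comes from a single change on the aromatic ring that carries the sulfonamide, so this position has already shown that it matters.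

Compound 3, `COc1ccc(N2C[C@@H](C)N[C@@H](C)C2)cc1NS(=O)(=O)c1ccc(OCc2ccccc2)cc1`, has not been measured. It differs from compound 2 in one place: benzyloxy in place of 2-oxopyrrolidin-1-yl on an aromatic carbon. For the measured compounds named here, no measured step involves benzyloxy, so the only guide is that changing this para group once moved this assay by a 7.9-fold lower number from compound 1 to compound 2 (0.90 log units; beyond the scatter), a modest amount. The new group is neither the pyridin-4-yl of compound 1 nor the lactam of compound 2, so a shift in either direction is possible. For compound 3 the expected result is a somewhat higher number than compound 2, a step of about a 2.5-fold higher number from compound 2 to compound 3 (0.40 log units; beyond the scatter), with an estimate of 100 nM and a range from 25 nM to 400 nM.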

Compound 3, half-maximal effective concentration: 100 nM
Compound 3: middle estimate and measured number agree at the digits printed; the range from low to high includes it.
By their numbers in this assay, from the lowest: compound 2; then compound 3; then compound 1.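

In this assay, the benzyloxy compound falls between the two earlier compounds: the step is a 2.5-fold higher number from compound 2 to compound 3 (0.40 log units; beyond the scatter) on one side and a 3.2-fold lower number from compound 1 to compound 3 (0.50 log units; beyond the scatter) on the other. This position on the ring therefore now separates three groups rather than two, giving a graded order instead of a single contrast. Among these three groups, 2-oxopyrrolidin-1-yl still gives the lowest number, yet pyridin-4-yl is not the only group it can be compared with, and benzyloxy, which has no lactam and carries a six-membered aromatic ring of carbon only, also gives a lower number than pyridin-4-yl. No accompanying evidence explains the order of the three groups.

The compounds shown leave open which part of benzyloxy matters, the oxygen link or the outer benzene ring, and a plain methoxy or phenyl group in the same place would help to separate the two. They also leave open whether the lactam ring itself is needed for the lowest number, which an open-chain acetamide or a six-membered piperidin-2-one ring at this position could test.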